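This account rests on a few compounds, and the source may have more. Where it says the series, first, only, none or still open, it means among the compounds named here.

For the measured compounds named here, in an ADME assay on a cell-free system (plasma, Mus musculus, strain CD-1) for metabolic stability, read by LC-MS, tested at 1 uM (on this read-out lower numbers stand for a shorter-lived compound and higher numbers for a longer-lived compound), compound 2 `O=C(CCc1nc2ccccc2c(=O)[nH]1)Nc1ccc(-c2c[nH]c(-c3ccccc3)n2)cc1` gives 0.883 h, the only exact number so far. Compound 1 `Cn1nc(-c2ccc(NC(=O)CCc3nc4ccccc4c(=O)[nH]3)cc2)c2ccccc21` reads > 16.6 h, which is a limit.

Compound 3 `Cn1c(-c2ccc(NC(=O)CCc3nc4ccccc4c(=O)[nH]3)cc2)nc2ccccc21` keeps the shared core of compound 2 and changes the group on an aromatic carbon of the six-membered aromatic ring of carbon only, para to a large group: a group of 10 heavy atoms (8 carbon, 2 nitrogen; one five-membered aromatic ring with 2 hetero atoms, one six-membered aromatic ring of carbon only) in place of a group of 11 heavy atoms (9 carbon, 2 nitrogen; one five-membered aromatic ring with 2 hetero atoms, one six-membered aromatic ring of carbon only), on an aromatic carbon. The entering group is 1-methyl-1H-benzimidazol-2-yl.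

Going by the values given here, one measured step bears on this change: an at least 18-fold lower number from compound 1 to compound 2 (1.27 log units; beyond the scatter). That step is large. It removes the same group that compound 3 removes, but in the opposite direction, and the group entering compound 3 matches the group of compound 1 in its counted composition. The two groups are still different, and a single step is thin support, so the range stays wide.

A rise in this assay beyond the scatter is therefore expected, probably large but of uncertain size. The expected change is a 9.1-fold higher number from compound 2 to compound 3 (0.96 log units; beyond the scatter). For compound 3 the estimated half-life is 8 h, with an expected range of 1.5 h to 30 h.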

Compound 3, half-life: > 8.33 h
Compound 3 ended at the assay's limit; the forecaster's own chance of this, stated with the estimate: 35%; middle value at least 1.0-fold (0.01 log units) from the limit.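

In this assay, placing 1-methyl-1H-benzimidazol-2-yl on the aromatic carbon para to a large group gives an at least 9.4-fold higher number from compound 2 to compound 3 (0.97 log units; beyond the scatter), so a second group at this place, alongside the 1-methyl-1H-indazol-3-yl of compound 1, reads far apart from the group of compound 2. The full size of this step stays unknown, as the reading of compound 3 is a limit and not a number: the limit of > 8.33 h in this assay, at which 1 of the 3 values shown sits. Compound 1 also ends at a limit, so the step from compound 1 to compound 3 cannot be read and the two fused groups cannot be ranked in this assay: the limit of > 16.6 h in this assay, at which 1 of the 3 values shown sits.

The group that leaves differs from the one that enters in more than one counted feature, with 1 hydrogen-bond donor against 0 and a different count of heavy atoms, and the compounds shown do not separate these differences. As far as these compounds go, a 1-methyl-2-phenyl-1H-imidazol-4-yl group at the same place would keep the phenyl and imidazole rings of compound 2 while removing the ring hydrogen on nitrogen, and its half-life remains open.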